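This account rests on a few compounds, and the source may have more. Where it says the series, first, only, none or still open, it means among the compounds named here.

Working notes, measured in a functional assay on HT-29 cells (Homo sapiens) for inhibition, read by MTT assay, with a stated time of 48 h; a lower number here means a stronger inhibitor, a higher number a weaker inhibitor:
- compound 1 `COc1ccc(-n2c(SC)nnc2-c2cc(OC)c(OC)c(OC)c2)cc1`: > 60000 nM (a limit)
- compound 2 `CCSc1nnc(-c2cc(OC)c(OC)c(OC)c2)n1-c1ccc(OC)cc1`: > 60000 nM (a limit)
- compound 3 `COc1ccc(CSc2nnc(-c3cc(OC)c(OC)c(OC)c3)n2-c2ccc(OC)cc2)cc1`: > 60000 nM (a limit)

Within the data shown here, the only reading across the series is the limit of > 60000 nM in this assay, at which 3 of the 3 values shown sit, so no compound carries a true number yet. Compound 2 with > 60000 nM has a limit and no number.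

Compound 4 `CCSc1nnc(-c2cc(OC)c(OC)c(OC)c2)n1-c1ccc(N(C)C)cc1` differs from compound 2 by dimethylamino in place of methoxy on an aromatic carbon, that is, 4-methoxyphenyl to 4-(dimethylamino)phenyl. The measured steps are a step that the two limits leave unreadable from compound 1 to compound 2, a step that the two limits leave unreadable from compound 1 to compound 3 and a step that the two limits leave unreadable from compound 2 to compound 3. All three fall on a saturated chain carbon bound to a sulfur, none has a readable size, and none alters the 4-methoxyphenyl group that changes here. They supply no size to carry over.

The expectation therefore rests on the flat series alone: compound 4 is expected to stay weak, with any change leaning towards stronger inhibition, since the start sits at a limit. In this assay the expected step is an at least 1.3-fold lower number from compound 2 to compound 4 (0.12 log units; that floor lies within the scatter), and it remains poorly constrained. For compound 4 the estimated value is 45000 nM, with an expected range from 8000 nM to 100000 nM and a substantial chance of another limit.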

Compound 4, half-maximal inhibitory concentration: > 60000 nM
Compound 4: only a limit was reported (the forecaster's own chance of this, stated with the estimate: 60%); middle value at least 1.3-fold (0.12 log units) from the limit.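

Compound 2 and compound 4 both carry only a limit in this assay, so the change from methoxy to dimethylamino gives no readable step. The compounds shown leave open what true number any of them would have, and how large a step either changed place could produce: the limit of > 60000 nM in this assay, at which 4 of the 4 values shown sit.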